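Swapping methoxy for fluoro on compound 3

This account rests on a few compounds, and the source may have more. Where it says the series, first, only, none or still open, it means among the compounds named here.

Measured so far in an ADME assay on HEK-293T cells (Homo sapiens) for cytotoxicity, read by MTT assay, with a stated time of 24 h; a lower number here means that less compound is tolerated, a higher number that more compound is tolerated:
- compound 1 `FC(F)(F)c1ccc(-c2nn(-c3ccccc3)cc2-c2nc3ccccc3[nH]2)cc1` gives 167000 nM
- compound 2 `Cc1ccc(-c2nn(-c3ccccc3)cc2-c2nc3ccccc3n2S(=O)(=O)c2ccc(C)cc2)cc1` gives 79300 nM
- compound 3 `COc1ccc(S(=O)(=O)n2c(-c3cn(-c4ccccc4)nc3-c3ccc(F)cc3)nc3ccccc32)cc1` gives 37300 nM

Compound 3 has the lowest number of the three in this assay, so the cells tolerate less of it than of compound 2 or compound 1. Both gaps lie beyond the usual scatter of repeated measurements.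

Compound 4 `O=S(=O)(c1ccc(F)cc1)n1c(-c2cn(-c3ccccc3)nc2-c2ccc(F)cc2)nc2ccccc21` differs from compound 3 in one place, with fluoro in place of methoxy on an aromatic carbon for a change that reads 4-methoxyphenyl to 4-fluorophenyl. Within the data shown here, no two measured compounds differ by this change alone, so the data give no direct guide to its size. The best anchor is compound 3 at 37300 nM. It is the closest measured structure. The change is therefore expected to be small, with an estimated 1.1-fold higher number from compound 3 to compound 4 (0.03 log units; within the scatter) that stays within the usual scatter and has no firm direction. For compound 4 the estimated value is 40000 nM with an expected range from 15000 nM to 100000 nM in this measurement.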

Compound 4, half-maximal cytotoxic concentration: 218000 nM
Estimate against measurement, compound 4: 5.5-fold (0.74 log units) below, outside the stated range (above it).
By their numbers in this assay, from the lowest: compound 3; then compound 2; then compounds 1 and 4 (each within the scatter of the next).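

In this assay, the change from (4-methoxyphenyl)sulfonyl to (4-fluorophenyl)sulfonyl gives a 5.8-fold higher number from compound 3 to compound 4 (0.77 log units; beyond the scatter), so this position on the aromatic ring, para to a large group, is not a silent one. This is the only step shown between compounds that differ in one place, and it gives the first direct sign that exchanging one small group here can shift how much compound the cells tolerate, with more tolerated when fluoro is present. Nothing available explains why the swap has this size or direction.

A single pair cannot show whether the step follows from losing methoxy or from gaining fluoro, and a chloro group or an amine at the same place would help to separate the two. As far as these compounds go, whether the same swap has a similar size on a different core also remains open.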